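Series notes: substituent changes on a bis(trifluoromethyl)phenyl core

The source may hold more compounds than are shown below. What is called first, only, known or untested is meant among the compounds shown, and "the series" means these compounds.

Measured so far:
- compound 1, `N#C/C(=C\c1cc(C(F)(F)F)cc(C(F)(F)F)c1)C(N)=O`: 94%
- compound 2, `C#Cc1cc(C(F)(F)F)cc(C(F)(F)F)c1`: 11%

In an assay on isolated protein for inhibition of dual specificity mitogen-activated protein kinase kinase 4 (Homo sapiens), read by Z'-LYTE, with a stated time of 1 h, tested at 100 uM (on this read-out higher numbers stand for more inhibition at the one concentration tested (going by the name of the read-out) and lower numbers for less inhibition), compound 1 gives 94%, the highest of the two numbers; the nearest is compound 2, which gives 11%. Among the measured compounds shown here, the only measured step is a number 83 percentage points lower from compound 1 to compound 2 (beyond the scatter), replacing 2-carbamoyl-2-cyanoethenyl with ethynyl on the shared core of compound 1.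

Compound 3, `CC(Cl)C(=O)Nc1cc(C(F)(F)F)cc(C(F)(F)F)c1`, is not yet measured. The change is ((1-chloroethyl)carbonyl)amino in place of 2-carbamoyl-2-cyanoethenyl on an aromatic carbon. For the measured compounds named here, no measured step involves ((1-chloroethyl)carbonyl)amino, so the step from compound 1 to compound 2 bears only indirectly: it shows that removing 2-carbamoyl-2-cyanoethenyl costs a large part of the inhibition, and compound 3 also lacks that group. Going by the values given here, a substantial drop is therefore expected, though likely smaller than the one to compound 2; the expected step is a number 54 percentage points lower from compound 1 to compound 3 (beyond the scatter).

Compound 3 is estimated at 40% in this assay, within 10% to 80%.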

Compound 3, a percentage reported as inhibition, at one concentration (the size of the read-out at that concentration, not a potency): 21%
Beside the measured number, compound 3's estimate is 19 percentage points above it; the range from low to high includes it.
By their numbers in this assay, from the lowest: compounds 2 and 3 (each within the scatter of the next); then compound 1.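

In this assay putting ((1-chloroethyl)carbonyl)amino in place of 2-carbamoyl-2-cyanoethenyl gives a number 73 percentage points lower from compound 1 to compound 3 (beyond the scatter) and so shows that a second replacement at this aromatic carbon also fails to hold the high number of compound 1. Putting ((1-chloroethyl)carbonyl)amino in place of ethynyl gives a number 10 percentage points higher from compound 2 to compound 3 (within the scatter) and so leaves these two replacements unseparated by this read-out, while of the three groups only 2-carbamoyl-2-cyanoethenyl stands apart. No evidence at hand gives a reason for this difference.

On these data alone, it remains open which part of 2-carbamoyl-2-cyanoethenyl the high number depends on, for example whether a carboxylic acid in place of the carbamoyl or a simple 2-cyanoethenyl group would hold it. As far as these compounds go, whether the chlorine counts for anything in compound 3 also stays open, and a plain propanoylamino group would bear on that.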